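The source may hold more compounds than are shown below. What is called first, only, known or untested is meant among the compounds shown, and "the series" means these compounds.

In an ADME assay on Huh-7 cells (Homo sapiens) for cytotoxicity (on this read-out lower numbers stand for higher toxicity in this test and higher numbers for lower toxicity in this test), compound 2 `NC(=S)Nc1cccc(OCCCCCCCCNC(=S)Nc2cc(Cl)cc(Cl)c2)c1` gives 12000 nM, the lowest of the two numbers recorded, while compound 1 `NC(=S)Nc1cccc(OCCCCCN2CCCCN(c3ccc(Cl)cc3)C2=O)c1` gives 13000 nM, a gap that sits within the scatter. Within the data shown here, no step between compound 1 and compound 2 is counted, since they differ in more than one place. Compound 3 `NC(=S)Nc1cccc(OCCCCCCCCNC(=S)Nc2ccc3[nH]ccc3c2)c1` differs from compound 2 by 1H-indol-5-yl in place of 3,5-dichlorophenyl on an amide-type nitrogen. Among the measured compounds shown here, no step of this kind has been measured, so a change no larger than the scatter is expected from compound 2 to compound 3, namely a 1.2-fold higher number from compound 2 to compound 3 (0.07 log units; within the scatter). Compound 3 is therefore estimated at 14000 nM, within 5000 nM to 40000 nM.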

Compound 3, half-maximal cytotoxic concentration: 18000 nM
Compound 3: the middle estimate sits 1.3-fold (0.11 log units) below what was measured; the range from low to high includes it.
By their numbers in this assay, from the lowest: compounds 2, 1 and 3 (each within the scatter of the next).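

In this assay, among these compounds, the change to 1H-indol-5-yl in place of 3,5-dichlorophenyl on an amide-type nitrogen gives a 1.5-fold higher number from compound 2 to compound 3 (0.18 log units; within the scatter) and is the first step that can be read at this position. Here, a group with two aromatic rings, a hydrogen-bond donor and no chlorine replaces the dichlorinated ring without a change beyond the scatter. Nothing available accounts for this result.

From the compounds shown here alone, whether a pyridine ring, a carboxylic acid or an amine at this position would also stay within the scatter remains open. The effect of a longer chain is open too.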